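The source may hold more compounds than are shown below. What is called first, only, known or untested is meant among the compounds shown, and "the series" means these compounds.

Measured so far:
- compound 1 `Cc1cc(C)c(NC(=O)N(Cc2cccc(-c3nnnn3C)c2)C2CCCCCC2)c(C)c1` — in a functional assay on a cell-free system (plasma) with sterol O-acyltransferase, Soat (Rattus norvegicus) as the target (on this read-out lower numbers stand for an effect already at smaller amounts and higher numbers for an effect only at larger amounts of compound), compound 1 sits at the assay limit > 1 mg/kg, a bound rather than a number.
- compound 2 `Cc1cc(C)c(NC(=O)N(Cc2cccc(-c3cn[nH]c3)c2)C2CCCCCC2)c(C)c1` — in this assay compound 2 gives 0.19 mg/kg.

For the measured compounds named here, compound 2 thus carries the only real number in this assay; the other entry is a limit. Compound 3 `Cc1cc(C)c(NC(=O)N(Cc2cccc(-c3ccnn3C)c2)C2CCCCCC2)c(C)c1` differs from it by 1-methyl-1H-pyrazol-5-yl in place of 1H-pyrazol-4-yl on an aromatic carbon. Going by the values given here, the one measured step that bears on this is an at least 5.2-fold lower number from compound 1 to compound 2 (0.72 log units; beyond the scatter), a move from a methylated azole without a donor to the pyrazole with one; its size is known only as a bound because compound 1 sits at the limit of > 1 mg/kg in this assay, at which 1 of the 2 values shown sits. Compound 3 returns to a methylated azole with no donor, so a rise in the number beyond the scatter is expected, though the true size is uncertain. Compound 3 is therefore estimated at 0.8 mg/kg, within 0.3 mg/kg to 3 mg/kg. This corresponds to an expected step of a 4.2-fold higher number from compound 2 to compound 3 (0.62 log units; beyond the scatter).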

Compound 3, dose for half-maximal effect: > 1 mg/kg
Compound 3: a limit, no number (the forecaster's own chance of this, stated with the estimate: 40%); middle value at least 1.2-fold (0.09 log units) from the limit.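

In this assay compound 3 gives > 1 mg/kg, a limit and not a number. Keeping a five-membered aromatic ring with 2 hetero atoms on the aromatic carbon does not keep the effect: the change to 1-methyl-1H-pyrazol-5-yl gives an at least 5.2-fold higher number from compound 2 to compound 3 (0.72 log units; beyond the scatter), so the loss is not tied to the tetrazole ring, and among the three compounds only the group with a hydrogen-bond donor gives a number. The step between the two methylated azoles cannot be read, and the size of both steps to compound 2 remains a bound: the limit of > 1 mg/kg in this assay, at which 2 of the 3 values shown sit.

As far as these compounds go, this change moves the ring attachment and adds the methyl together, so the share of each stays open. A 1-methyl-1H-pyrazol-4-yl group would separate the two, and an imidazole or a carboxylic acid would test whether another group carrying such a hydrogen can stand in for the pyrazole.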